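The compounds below may be only part of what the source reports. "The series", "measured", "known", "first", "only" and "open" are said of these compounds alone.

Compound 3 `COc1cc(OC)c(C(=O)/C=C/c2ccc(F)cc2)c(OC)c1` carries a fluoro group on the aromatic carbon of the phenyl ring that bears the enone. In a functional assay on HaCaT cells (Homo sapiens), read by fluorescence and BrdU incorporation, with a stated time of 48 h, tested at 10 uM (a higher number here means a weaker effect of the compound at the concentration tested, a lower number a stronger effect), compound 3 gives 20%. The unsubstituted parent compound 1 `COc1cc(OC)c(C(=O)/C=C/c2ccccc2)c(OC)c1` gives in this assay 18%, and the chloro analogue compound 2 `COc1cc(OC)c(C(=O)/C=C/c2ccc(Cl)cc2)c(OC)c1` gives in this assay 26%. The three numbers sit close together: a number 2 percentage points higher from compound 1 to compound 3 (within the scatter), a number 6 percentage points lower from compound 2 to compound 3 (within the scatter), and a number 8 percentage points higher from compound 1 to compound 2 (within the scatter). Compound 3 thus stands alongside both neighbours with no separation beyond the usual scatter.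

Compound 4 `COc1cc(OC)c(C(=O)/C=C/c2ccc(Br)cc2)c(OC)c1` differs from compound 3 as follows: bromo in place of fluoro on an aromatic carbon.

Among the measured compounds shown here, the steps that bear on this change are the halogen exchanges at the same aromatic carbon, namely a number 8 percentage points higher from compound 1 to compound 2 (within the scatter), a number 2 percentage points higher from compound 1 to compound 3 (within the scatter) and a number 6 percentage points lower from compound 2 to compound 3 (within the scatter); each is a halogen for hydrogen or halogen for halogen swap, and none moves the read-out beyond the scatter. Exchanging one halogen for another at this position is therefore expected to give no step beyond the scatter in this assay: a number 5 percentage points higher from compound 3 to compound 4 (within the scatter). Compound 4 is estimated at 25%, with a range from 14% to 38%.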

Compound 4, a percentage reported as activity, at one concentration (the size of the read-out at that concentration, not a potency): 24%
Beside the measured number, compound 4's estimate is 1 percentage points above it; the measured number falls inside the stated range.
By their numbers in this assay, from the lowest: compounds 1, 3, 4 and 2 (each within the scatter of the next).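

Bromo completes a run of halogens on this aromatic carbon, para to a large group: the change from 4-fluorophenyl to 4-bromophenyl gives a number 4 percentage points higher from compound 3 to compound 4 (within the scatter) in this assay and adds no separation. The exchange for chloro gives a number 2 percentage points lower from compound 2 to compound 4 (within the scatter) and the exchange for hydrogen gives a number 6 percentage points higher from compound 1 to compound 4 (within the scatter), so among compounds 1 to 4 no substituent at this position stands apart from another. No measured data on these groups are available to account for this flat result.

The compounds shown leave open whether a group that is not a halogen at this position, such as an amine, a carboxylic acid or a longer chain, would move the read-out beyond the scatter. They also leave open whether these halogen exchanges stay as flat on a different core.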